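The source may hold more compounds than are shown below. What is called first, only, known or untested is meant among the compounds shown, and "the series" means these compounds.

In an assay on CHO cells for displacement of a labelled ligand from 5-hydroxytryptamine receptor 1D (Homo sapiens) (a higher number here means a weaker inhibitor, a lower number a stronger inhibitor), the measured compounds stand as follows:
compound 1 `CC(C)=CCCN(C)C1CCN(CCCc2c[nH]c3ccc(-n4cnnc4)cc23)CC1` gives 2.6 nM;
compound 2 `c1cncc(CNC2CCN(CCCc3c[nH]c4ccc(-n5cnnc5)cc34)CC2)c1` gives 35 nM;
compound 3 `c1ccc(NCC2CCN(CCCc3c[nH]c4ccc(-n5cnnc5)cc34)CC2)nc1` gives 1.7 nM.

Compound 3 holds the lowest number of the three, but one of its steps, a 1.5-fold lower number from compound 1 to compound 3 (0.18 log units; within the scatter), lies within the scatter, so those two cannot be ordered; its other step is a 21-fold lower number from compound 2 to compound 3 (1.31 log units; beyond the scatter). Compound 4 `CN(Cc1cccs1)C1CCN(CCCc2c[nH]c3ccc(-n4cnnc4)cc23)CC1` differs from compound 3 in one place: methyl((thiophen-2-yl)methyl)amino in place of ((pyridin-2-yl)amino)methyl on a saturated ring carbon. The step that bears on this is a 13-fold higher number from compound 1 to compound 2 (1.13 log units; beyond the scatter), where a methyl-bearing amine gave way to a secondary amine carrying an aromatic methyl group; compound 4 keeps the methyl on the amine, as compound 1 does. A moderate rise in the number is therefore expected, a 4.7-fold higher number from compound 3 to compound 4 (0.67 log units; beyond the scatter). Compound 4 is estimated at 8 nM, in the range 2.5 nM to 30 nM.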

Compound 4, half-maximal inhibitory concentration: 4.3 nM
Compound 4: middle estimate off by 1.9-fold (0.27 log units), on the high side, and the stated range covers the measured number.
By their numbers in this assay, from the lowest: compounds 3, 1 and 4 (each within the scatter of the next, the first and the last beyond it); then compound 2.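

In this assay, the thiophen-2-yl ring of compound 4 can stand on the methyl-bearing amine in place of the 3-methylbut-2-en-1-yl group with no readable change: a 1.7-fold higher number from compound 1 to compound 4 (0.22 log units; within the scatter). An aromatic ring on this amine therefore does not by itself bring the high number of compound 2, as an 8.1-fold lower number from compound 2 to compound 4 (0.91 log units; beyond the scatter) shows. The entering group has no hydrogen-bond donor, yet the step from the ((pyridin-2-yl)amino)methyl group stays modest: a 2.5-fold higher number from compound 3 to compound 4 (0.40 log units; beyond the scatter).

Whether the amine methyl or the thiophen-2-yl ring accounts for the gap to compound 2 remains open, since those two compounds differ in both. Also open is what a phenyl ring or a longer chain between the amine and the ring would give, and no evidence is offered for the cause of any of these steps.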